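Indazole substituent swap in the acrylic acid series

A few compounds are considered here, and "the series" means these few. Any claim that something is new, unique, unknown or untested is made for them only; others in the source may bear on it.

compound 1 `CC/C(=C(/c1ccc(/C=C/C(=O)O)cc1)c1cnc2[nH]ncc2c1)c1ccccc1`: 302 nM
compound 2 `CC/C(=C(/c1ccc(/C=C/C(=O)O)cc1)c1cc(C)c2[nH]ncc2c1)c1ccccc1`: 59 nM
compound 3 `CC/C(=C(/c1ccc(/C=C/C(=O)O)cc1)c1cc2cn[nH]c2cc1F)c1ccccc1`: 47 nM

In a functional assay on MCF7 cells (Homo sapiens) for cytotoxicity, read by CellTiter-Glo, with a stated time of 5 days (a lower number here means a stronger inhibitor, a higher number a weaker inhibitor), compound 3 gives 47 nM; compound 2 sits within the scatter of it, compound 1 well beyond. Compound 4 `CC/C(=C(/c1ccc(/C=C/C(=O)O)cc1)c1ccc2[nH]ncc2c1Cl)c1ccccc1` carries 4-chloro-1H-indazol-5-yl in place of 6-fluoro-1H-indazol-5-yl on a double-bonded chain carbon bound to an aromatic carbon and a double-bonded chain carbon. Both substituted indazoles moved away from the unsubstituted one: a 5.1-fold lower number from compound 1 to compound 2 (0.71 log units; beyond the scatter) and a 6.4-fold lower number from compound 1 to compound 3 (0.81 log units; beyond the scatter), whereas a 1.3-fold lower number from compound 2 to compound 3 (0.10 log units; within the scatter). The two substituted analogues sit close together, so a third substitution pattern is expected to stay near them, with no step beyond the scatter. The expected step is a 1.3-fold higher number from compound 3 to compound 4 (0.11 log units; within the scatter). Compound 4 is estimated at 60 nM, with an expected range from 25 nM to 150 nM.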

Compound 4, half-maximal inhibitory concentration: 1.6 nM
Compound 4: middle estimate off by 38-fold (1.57 log units), on the high side; measured number outside the range, below it.
By their numbers in this assay, from the lowest: compound 4; then compounds 3 and 2 (each within the scatter of the next); then compound 1.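

In this assay the substituent on the indazole at this double-bonded chain carbon is far from interchangeable: 4-chloro-1H-indazol-5-yl gives a 29-fold lower number from compound 3 to compound 4 (1.47 log units; beyond the scatter) and a 37-fold lower number from compound 2 to compound 4 (1.57 log units; beyond the scatter) even though the fluoro and methyl analogues lay within the scatter of each other. The step of a 190-fold lower number from compound 1 to compound 4 (2.28 log units; beyond the scatter) also exceeds what either of those substituted analogues gained over compound 1. No available data bear on the origin of this gain.

From the compounds shown here alone, whether the gain follows the chlorine itself or its place on the indazole stays open. A bromine or a methyl group in place of the chlorine of 4-chloro-1H-indazol-5-yl would test the first of these.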